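A few compounds are considered here, and "the series" means these few. Any claim that something is new, unique, unknown or untested is made for them only; others in the source may bear on it.

Among the measured compounds shown here, compound 3 `Cc1ccc(C(C)C)c(OC(=O)c2cn(-c3ccccc3)nc2-c2ccncc2)c1` is the only compound of this small set with a measured number: in a functional assay on HL-60 cells (Homo sapiens) for cytotoxicity, read by MTT assay, with a stated time of 48 h (on this read-out higher numbers stand for weaker inhibition and lower numbers for stronger inhibition), compound 3 gives 17800 nM. Compound 1 `COc1ccc(OC(=O)c2cn(-c3ccccc3)nc2-c2ccncc2)cc1` reaches only a limit of the assay, > 100000 nM in this assay. Compound 2 `CC(C)c1cccc(OC(=O)c2cn(-c3ccccc3)nc2-c2ccncc2)c1` is recorded in this assay as "nd(insoluble)" (no result reported), without a number. For the measured compounds named here, the one measured step, an at least 5.6-fold lower number from compound 1 to compound 3 (0.74 log units; beyond the scatter), is known only as a lower bound because the limit of > 100000 nM in this assay, at which 1 of the 3 values shown sits, applies to compound 1.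

Compound 4 `O=C(Oc1ccc2ccccc2c1)c1cn(-c2ccccc2)nc1-c1ccncc1` differs from compound 3 in one place: naphthalen-2-yl in place of 2-isopropyl-5-methylphenyl on an oxygen next to a carbonyl group. Going by the values given here, the single measured step concerns the same oxygen next to the carbonyl group, where swapping one substituted phenyl ring for another moved the number from a limit to a value, but it gives no direct guidance on a naphthalen-2-yl ring, and no other measured pair addresses this position. A step of about the size a 1.1-fold higher number from compound 3 to compound 4 (0.05 log units; within the scatter) is therefore expected, which amounts to no confident change beyond the scatter. Compound 4 is estimated at 20000 nM, with a range from 5000 nM to 100000 nM.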

Compound 4, half-maximal inhibitory concentration: > 100000 nM
Compound 4 gave a limit, no number; the forecaster's own chance of this, stated with the estimate: 25%; at least 5.0-fold (0.69 log units) between middle value and limit.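

In this assay, naphthalen-2-yl in place of 2-isopropyl-5-methylphenyl on an oxygen next to a carbonyl group gives an at least 5.6-fold higher number from compound 3 to compound 4 (0.74 log units; beyond the scatter), so this position can lose the response as well as gain it. The two groups have the same count of heavy atoms and differ in having two aromatic rings against one, so the heavy-atom count alone does not fix the result among these compounds. Compound 1 and compound 4 both stand at a limit, and the step between them cannot be read: the limit of > 100000 nM in this assay, at which 2 of the 4 values shown sit.

The compounds shown leave open whether an amine or a carboxylic acid on the phenyl ring at this position would give a measured number. They also do not separate the contributions of the isopropyl and methyl groups of compound 3, since compound 2 has no number.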